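Amino in place of nitro: compound 3 to compound 4

The source may report more compounds than this note shows. Statements on the series, on what has been measured and on what is new or still open speak of the compounds shown alone.

In a functional assay on HT-1080 cells (Homo sapiens) for antiproliferative activity, read by MTT assay, with a stated time of 72 h (a higher number here means a weaker inhibitor, a lower number a stronger inhibitor), compound 1 `COc1ccc(-c2ssc(=S)c2-c2cc(OC)c(OC)c(OC)c2)cc1[N+](=O)[O-]` gives 9140 nM, compound 2 `COc1ccc(-c2c(-c3cc(OC)c(OC)c(OC)c3)ssc2=S)cc1` gives 2270 nM and compound 3 `COc1ccc(-c2c(-c3cc(OC)c(OC)c(OC)c3)ssc2=S)cc1[N+](=O)[O-]` gives 3550 nM. Compound 3 stands within the scatter of compound 2, and its number lies lower than that of compound 1 by more than the scatter.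

Compound 4 `COc1ccc(-c2c(-c3cc(OC)c(OC)c(OC)c3)ssc2=S)cc1N` follows from compound 3 by one change, amino in place of nitro on an aromatic carbon. For the measured compounds named here, no amino compound has been measured in this assay. Going by the values given here, one measured step bears on the same aromatic carbon: a 1.6-fold higher number from compound 2 to compound 3 (0.19 log units; within the scatter), nitro in place of hydrogen, and it stays within the scatter. On the strength of that small step for compound 3, no change beyond the scatter is expected, with a slight lean towards a lower number. The expected step is a 1.6-fold lower number from compound 3 to compound 4 (0.21 log units; within the scatter). For compound 4 the estimate is 2200 nM, with an expected range of 700 nM to 7000 nM.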

Compound 4, half-maximal inhibitory concentration: 3000 nM
Estimate against measurement, compound 4: 1.4-fold (0.13 log units) below; the range from low to high includes it.
By their numbers in this assay, from the lowest: compounds 2, 4 and 3 (each within the scatter of the next); then compound 1.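

In this assay the amino group, on an aromatic carbon ortho to a methoxy group, stays within the scatter of both earlier compounds at this position: a 1.2-fold lower number from compound 3 to compound 4 (0.07 log units; within the scatter) and a 1.3-fold higher number from compound 2 to compound 4 (0.12 log units; within the scatter). Until now this position offered only the comparison of nitro with hydrogen, so the series now has three groups here that this read-out does not separate. That holds even though the amino group brings a hydrogen-bond donor that nitro lacks, and nothing at hand explains this flat result.

Still open, as far as these compounds go, is whether a larger group on this carbon, such as an acetamide or a carboxylic acid, would leave the scatter. Also open, from the compounds shown here alone, is whether amino in place of nitro gives as small a step on the arrangement of compound 1 .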